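Swapping One Halogenated Phenyl for Another on a Shared Core

The source may report more compounds than this note shows. Statements on the series, on what has been measured and on what is new or still open speak of the compounds shown alone.

Measured so far:
Compound 1, `Cc1cc(=O)c2c(O)c(CN3CCC(Cc4ccccc4)CC3)c(O)c([C@H]3CCN(C)C[C@H]3O)c2o1`: 21%
Compound 2, `Cc1oc2c([C@H]3CCN(C)C[C@H]3O)c(O)cc(O)c2c(=O)c1C(O)c1cccc(Cl)c1`: 4%

Both compounds were tested in a functional assay on Caco-2 cells (Homo sapiens) for inhibition, read by MTT assay, with a stated time of 48 h, tested at 10 uM; a lower number here means less inhibition of growth, a higher number more inhibition of growth at the concentration tested. Compound 2 stands at the lower of the two numbers, and compound 1 sits higher by a gap that is beyond the usual scatter, so the two are genuinely apart. Compound 3, `Cc1oc2c([C@H]3CCN(C)C[C@H]3O)c(O)cc(O)c2c(=O)c1C(O)c1ccc(F)cc1`, has not yet been measured. It differs from compound 2 in a single place: 4-fluorophenyl in place of 3-chlorophenyl on a saturated chain carbon bound to an aromatic carbon and an oxygen on a saturated carbon. The groups that leave and enter have the same heavy-atom count and the same ring type, and neither brings a donor or acceptor. Within the data shown here, no pair of measured compounds shows a change of this kind, so there is no measured step to lean on. The step of a number 3 percentage points higher from compound 2 to compound 3 (within the scatter) is expected to be small and within the usual scatter, in no clear direction. Compound 3 is therefore expected to give about 7%, in a range from -5% to 20%.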

Compound 3, percent growth inhibition at one concentration: 11%
Estimate against measurement, compound 3: 4 percentage points below; measured number inside the range.
By their numbers in this assay, from the lowest: compounds 2, 3 and 1 (each within the scatter of the next, the first and the last beyond it).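

Exchanging 3-chlorophenyl for 4-fluorophenyl on this saturated chain carbon gives, in this assay, a number 7 percentage points higher from compound 2 to compound 3 (within the scatter). At this position, then, one halogenated phenyl can stand in for the other without a difference that this read-out can separate from ordinary scatter, although the halogen and its place on the ring both change in the same swap, and this single step cannot tell those two changes apart. No measurement that could explain this result is available.

On these data alone, it remains open whether a group of a different kind at this place, such as an unsubstituted phenyl, a pyridine ring or an aminomethyl chain, would give a step beyond the scatter. Compound 1 differs from compound 2 and compound 3 in more than one place, so its number cannot be traced to any single group.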